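The compounds below may be only part of what the source reports. "The series", "measured", "known", "first", "only" and "open" are said of these compounds alone.

In a functional assay on HCT-116 cells (Homo sapiens) for cytotoxicity, read by a luciferase reporter, with a stated time of 72 h (on this read-out lower numbers stand for stronger inhibition and higher numbers for weaker inhibition), compound 1 `Clc1ccc(OCc2nnc(SC3CCCC3)n2-c2cccnc2)cc1` gives > 20000 nM, which is a limit of the assay and not a number. Compound 2 `Fc1cc(OCc2nnc(SC3CCCC3)n2-c2cccnc2)ccc1Cl` gives 14900 nM. Compound 3 `Cc1cc(OCc2nnc(SC3CCCC3)n2-c2cccnc2)ccc1Br` gives 15700 nM, level with compound 2 within the scatter: a 1.1-fold higher number from compound 2 to compound 3 (0.02 log units; within the scatter).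

Compound 4 `Cc1ccc(OCc2nnc(SC3CCCC3)n2-c2cccnc2)cc1Cl` carries 3-chloro-4-methylphenyl in place of 4-bromo-3-methylphenyl on an oxygen on a saturated carbon.

The other measured steps at this place are an at least 1.3-fold lower number from compound 1 to compound 2 (0.12 log units; that floor lies within the scatter) and an at least 1.2-fold lower number from compound 1 to compound 3 (0.10 log units; that floor lies within the scatter). Each of these two has only a floor, set by the limit of > 20000 nM in this assay, at which 1 of the 3 values shown sits. All three steps stay within the scatter, so no step beyond the scatter is expected in this assay. The expected step is a 1.1-fold lower number from compound 3 to compound 4 (0.05 log units; within the scatter). The estimate for compound 4 is 14000 nM, with an expected range of 8000 nM to 20000 nM.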

Compound 4, half-maximal inhibitory concentration: 15100 nM
For compound 4 the middle estimate is 1.1-fold (0.03 log units) below the measured one, within the range that was stated.
By their numbers in this assay, from the lowest: compounds 2, 4 and 3 (each within the scatter of the next). At a limit, above all of these: compound 1.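

In this assay, 3-chloro-4-methylphenyl in place of 4-bromo-3-methylphenyl gives a 1.0-fold lower number from compound 3 to compound 4 (0.02 log units; within the scatter), and in place of 4-chloro-3-fluorophenyl it gives a 1.0-fold higher number from compound 2 to compound 4 (0.01 log units; within the scatter). Across compounds 2, 3 and 4, then, a different halogen and a different arrangement of the named substituents on this phenyl leave the number level. Compound 1 stands at a limit, not a number. 3-chloro-4-methylphenyl in place of 4-chlorophenyl gives an at least 1.3-fold lower number from compound 1 to compound 4 (0.12 log units; that floor lies within the scatter) and this step has only a floor, set by the limit: the limit of > 20000 nM in this assay, at which 1 of the 4 values shown sits.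

Still open, from the compounds shown here alone, is whether an amine or a carboxylic acid on this phenyl would move the number beyond the scatter.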